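The source may report more compounds than this note shows. Statements on the series, on what has been measured and on what is new or still open speak of the compounds shown alone.

Measured in a functional assay (strain AB) with Danio rerio as the target, read by microscopy, with a stated time of 1 h; on this read-out higher numbers stand for an effect only at larger amounts of compound and lower numbers for an effect already at smaller amounts:
- Compound 1 `CCC1CCc2c(sc(NC(=O)Nc3ccc(Cl)cc3)c2C(N)=O)C1`: > 25000 nM (a limit of the assay, not a number)
- Compound 2 `NC(=O)c1c(NC(=O)Nc2ccc(Cl)cc2)sc2c1CCN(CC1CCC1)C2`: 1360 nM
- Compound 3 `CC(C)(C)C[N+]1(C)CCc2c(sc(NC(=O)Nc3ccc(Cl)cc3)c2C(N)=O)C1`: 290 nM

Compound 2, at 1360 nM, has the higher of the two true numbers. Compound 3, at 290 nM, lies lower by more than the usual scatter.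

Compound 4 `CC(C)N1CCc2c(sc(NC(=O)Nc3ccc(Cl)cc3)c2C(N)=O)C1` carries isopropyl in place of cyclobutylmethyl on an amine nitrogen in a ring. Among the compounds with values here, no measured pair isolates this change, so the expectation leans only on compound 2 at 1360 nM and stays loose. The expected change is a 1.3-fold higher number from compound 2 to compound 4 (0.12 log units; within the scatter), which would stay within the usual scatter. For compound 4 the estimated value is 1800 nM, with an expected range of 450 nM to 7000 nM.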

Compound 4, half-maximal effective concentration: 1490 nM
The estimate for compound 4 lay 1.2-fold (0.08 log units) above the measured number; low and high end bracket the measured number.
By their numbers in this assay, from the lowest: compound 3; then compounds 2 and 4 (each within the scatter of the next). At a limit, above all of these: compound 1.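

In this assay, replacing cyclobutylmethyl with isopropyl on the amine nitrogen in the ring gives a 1.1-fold higher number from compound 2 to compound 4 (0.04 log units; within the scatter). Neither the four-membered ring of carbon nor the two additional heavy atoms of cyclobutylmethyl is therefore needed at this position to keep the number at this level. Nothing available explains why the two groups match.

Within the data shown here, only two plain carbon groups are compared directly here, and both have no hydrogen-bond donors or acceptors. On these data alone, whether a longer chain, or a chain ending in a carboxylic acid or a hydroxyl group, would fit this nitrogen equally well remains open.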